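This account rests on a few compounds, and the source may have more. Where it says the series, first, only, none or still open, it means among the compounds named here.

Compound 1 `Oc1cccc(-c2cc(-c3ccc(Cl)cc3)nc(-c3cccs3)c2)c1`: 11800 nM
Compound 2 `Oc1cccc(-c2cc(-c3cccnc3)nc(-c3ccccc3Cl)c2)c1`: "not determined" (no result reported)

In an ADME assay on HEK293 cells (Homo sapiens) for cytotoxicity, read by CCK-8 assay and cell counting, with a stated time of 2 days (on this read-out higher numbers stand for weaker inhibition and lower numbers for stronger inhibition), compound 1 gives 11800 nM. Compound 2 has no number in this assay, so it stands nowhere on the scale shown, and only compound 1 offers a reference point. Compound 3 `Oc1cccc(-c2cc(-c3cccs3)nc(-c3ccccc3Cl)c2)c1` differs from compound 2 by thiophen-2-yl in place of pyridin-3-yl on an aromatic carbon. Going by the values given here, no step between two measured compounds exists here, so the size and direction of this change cannot be read from the data; a move no larger than the scatter is expected. Compound 3 is therefore estimated at 12000 nM, within a range from 4000 nM to 40000 nM.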

Compound 3, half-maximal inhibitory concentration: 2600 nM
Estimate against measurement, compound 3: 4.6-fold (0.66 log units) above; the whole stated range lies above it.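

In this assay, moving the chlorine on the phenyl group changes the number with thiophen-2-yl held in place: 2-chlorophenyl in place of 4-chlorophenyl gives a 4.5-fold lower number from compound 1 to compound 3 (0.66 log units; beyond the scatter) as a modest step. The exchange of pyridin-3-yl for thiophen-2-yl cannot be read, as compound 2 has no number. Nothing measured here explains the step. The compounds shown leave open whether a methoxy group or an amine in place of the chlorine would move the number, and whether the step from 4-chlorophenyl to 2-chlorophenyl would recur with pyridin-3-yl on the core.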